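Cytotoxicity in liver cells along a macrocyclic series

The source may report more compounds than this note shows. Statements on the series, on what has been measured and on what is new or still open speak of the compounds shown alone.

Measured so far in an ADME assay on Huh-7 cells (Homo sapiens) for cytotoxicity; on this read-out higher numbers stand for lower toxicity in this test and lower numbers for higher toxicity in this test:
Compound 1 `CCC[C@H](NC(=O)[C@@H]1C[C@@H]2CN1C(=O)[C@H](C(C)(C)C)NC(=O)OCCCCCc1cccc3c1CN(C3)C(=O)O2)C(=O)C(=O)NC1CC1`: compound 1 gives > 50000 nM, a limit of the assay.
Compound 2 `CCC[C@H](NC(=O)[C@@H]1C[C@@H]2CN1C(=O)[C@H](C1CCCC1)NC(=O)OCCCCCCc1cccc3c1CN(C3)C(=O)O2)C(=O)C(=O)CC1CC1`: compound 2 gives > 50000 nM, a limit of the assay.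
Compound 3 `CCC[C@H](NC(=O)[C@@H]1C[C@@H]2CN1C(=O)[C@H](C(C)(C)C)NC(=O)OCCCCCCc1cccc3c1CN(C3)C(=O)O2)C(=O)C(=O)NC1CCCC1`: compound 3 gives > 50000 nM, a limit of the assay.

Compound 3 therefore stands where every measured member of this set stands: at the limit of > 50000 nM in this assay, at which 3 of the 3 values shown sit. Among the compounds with values here, no compound in this group has yet returned a numerical value in this assay, so no step between two measured compounds can be sized.

Compound 4 `CCC[C@H](NC(=O)[C@@H]1C[C@@H]2CN1C(=O)[C@H](C(C)(C)C)NC(=O)OCCCCCCc1cccc3c1CN(C3)C(=O)O2)C(=O)C(=O)NC(C)c1ccccc1` differs from compound 3 in one place, (1-phenylethyl in place of cyclopentyl on an amide-type nitrogen), that is, 1-phenylethyl in place of cyclopentyl on an amide-type nitrogen. Within the data shown here, with no measured step to lean on, the expectation for compound 4 rests on the shared picture of compounds 1, 2 and 3, all of them at the limit. For compound 4 in this assay the estimate is 60000 nM, with a range from 20000 nM to 150000 nM. The step this estimate implies, a step that the limit leaves unreadable from compound 3 to compound 4, is expected to be none beyond the scatter, and it is expected that compound 4 will most likely again be reported only as a limit.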

Compound 4, half-maximal cytotoxic concentration: > 50000 nM
Compound 4 was reported as a limit; the forecaster's own chance of this, stated with the estimate: 75%; the middle value lies beyond the limit too.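

Compound 3 and compound 4 are both reported only as limits in this assay, so the step from cyclopentyl to 1-phenylethyl cannot be read: the limit of > 50000 nM in this assay, at which 4 of the 4 values shown sit.

The compounds shown leave open how far each lies beyond that limit, and which change, if any, would give a numerical value in this assay.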